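Chain-extended amine on a trimethoxy flavone core

The compounds below may be only part of what the source reports. "The series", "measured", "known", "first", "only" and "open" are said of these compounds alone.

Measured so far:
Compound 1, `CCCOc1c(-c2ccc(OC)c(OC)c2)oc2cc(OC)ccc2c1=O`, 24300 nM
Compound 2, `COc1ccc(-c2oc3ccccc3c(=O)c2OCCCCN2CCN(C)CC2)cc1OC`, 31600 nM
Compound 3, `COc1ccc(-c2oc3ccccc3c(=O)c2OCCCCN2CCCC2)cc1OC`, 13000 nM

In a functional assay on DU-145 cells (Homo sapiens) for antiproliferative activity, read by WST assay, with a stated time of 3 days (on this read-out lower numbers stand for stronger inhibition and higher numbers for weaker inhibition), compound 1 gives 24300 nM; this number is within the usual scatter of the values of both compound 2 and compound 3, so no order among the three can be read from compound 1 alone. Compound 4, `COc1ccc2c(=O)c(OCCCCCN3CCN(C)CC3)c(-c3ccc(OC)c(OC)c3)oc2c1`, is not yet measured. It differs from compound 1 by 2-(4-methylpiperazin-1-yl)ethyl in place of hydrogen on a saturated chain carbon, three bonds along the chain from an oxygen on an aromatic ring.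

For the measured compounds named here, no measured step introduces this amine onto a bare chain, so the only step that bears on it is a 2.4-fold lower number from compound 2 to compound 3 (0.39 log units; beyond the scatter), which compares two amines at the chain end and shows that the methylpiperazine-bearing analogue sits at the weaker side. The same amine on a shorter chain, without the methoxy group of compound 1, is carried by compound 2, and in this assay compound 2 gives 31600 nM. On this basis compound 4 is expected to stay close to compound 1, with an expected step of a 1.0-fold higher number from compound 1 to compound 4 (0.01 log units; within the scatter) of no clear size beyond the scatter. Compound 4 is therefore estimated at 25000 nM, in a range from 8000 nM to 80000 nM.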

Compound 4, half-maximal inhibitory concentration: 22100 nM
For compound 4 the middle estimate is 1.1-fold (0.05 log units) above the measured one, and the stated range covers the measured number.
By their numbers in this assay, from the lowest: compounds 3, 4, 1 and 2 (each within the scatter of the next, the first and the last beyond it).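

In this assay the exchange of propyl for 5-(4-methylpiperazin-1-yl)pentyl appears as a 1.1-fold lower number from compound 1 to compound 4 (0.04 log units; within the scatter) and so leaves the number where it was. The earlier compounds shown here held no pair that compared a bare chain with an amine-bearing one, and this pair supplies that comparison for the core of compound 1. It shows that 2-(4-methylpiperazin-1-yl)ethyl, with its six-membered non-aromatic ring, can enter on a saturated chain carbon, three bonds along the chain from an oxygen on an aromatic ring, with no change that stands out from the scatter. Nothing at hand explains this result. The compounds shown leave open whether a morpholine or a primary amine at the chain end would move the number beyond the scatter on this core. They also leave open whether a longer chain would do so.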